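This account rests on a few compounds, and the source may have more. Where it says the series, first, only, none or still open, it means among the compounds named here.

Measured so far in an ADME assay on MT4 cells (Homo sapiens) for cytotoxicity, read by MTT assay, with a stated time of 4 days; a lower number here means that less compound is tolerated, a higher number that more compound is tolerated:
- compound 1 `COc1ccc(/C=N/NC(=O)COc2cccc3ccccc23)cc1OC` gives 14.7 ug/mL
- compound 2 `O=C(COc1cccc2ccccc12)N/N=C/c1ccccc1` gives only a limit of the assay, >= 96.6 ug/mL
- compound 3 `O=C(COc1cccc2ccccc12)N/N=C/c1ccc(F)cc1` gives 65.1 ug/mL

Compound 3 stands highest of the two numbers shown; compound 1 lies lower by a margin beyond the usual scatter, and compound 2 sits at the limit of >= 96.6 ug/mL in this assay, at which 1 of the 3 values shown sits. Going by the values given here, the single measured step, an at least 1.4-fold lower number from compound 2 to compound 3 (0.17 log units; that floor lies within the scatter), is small, with its floor inside the scatter.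

Compound 4 `COc1ccc(/C=N/NC(=O)COc2cccc3ccccc23)cc1` differs from compound 3 by methoxy in place of fluoro on an aromatic carbon. No measured step involves a single methoxy, so the expectation rests on compound 1, which with two methoxy groups gives 14.7 ug/mL, the lowest number shown. A downward step is therefore expected, a 2.0-fold lower number from compound 3 to compound 4 (0.31 log units; beyond the scatter), landing between compound 3 and compound 1. Compound 4 is estimated at 32 ug/mL, with a range from 13 ug/mL to 80 ug/mL.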

Compound 4, half-maximal cytotoxic concentration: 76.9 ug/mL
Compound 4: the middle estimate sits 2.4-fold (0.38 log units) below what was measured, within the range that was stated.
By their numbers in this assay, from the lowest: compound 1; then compounds 3 and 4 (each within the scatter of the next). At a limit, above all of these: compound 2.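

In this assay, the change from 4-fluorophenyl to 4-methoxyphenyl, para to a large group, leaves the number flat: a 1.2-fold higher number from compound 3 to compound 4 (0.07 log units; within the scatter). Going by these compounds alone, a single methoxy here therefore does not carry the low number of the dimethoxy compound, since losing the second methoxy gives a 5.2-fold higher number from compound 1 to compound 4 (0.72 log units; beyond the scatter), the only new step beyond the scatter. Methoxy in place of hydrogen reads an at least 1.2-fold lower number from compound 2 to compound 4 (0.09 log units; that floor lies within the scatter), and its starting value is only a limit: the limit of >= 96.6 ug/mL in this assay, at which 1 of the 4 values shown sits.

As far as these compounds go, whether an amine or a carboxylic acid at this position would shift the number remains open. So does whether the lower number of compound 1 depends on where the second methoxy sits.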